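Moving Chlorine on a Trimethoxybenzohydrazone Series

This account rests on a few compounds, and the source may have more. Where it says the series, first, only, none or still open, it means among the compounds named here.

Measured compounds:
compound 1 `COc1cc(C(=O)N/N=C/c2cccc(F)c2)cc(OC)c1OC` gives 44.8%
compound 2 `COc1cc(C(=O)N/N=C/c2ccc(Cl)c(Cl)c2)cc(OC)c1OC` gives 32.7%

In a functional assay on BGC-823 cells (Homo sapiens) for antiproliferative activity, read by MTT assay, tested at 5 uM (a higher number here means a stronger effect of the compound at the concentration tested, a lower number a weaker effect), compound 2 stands lowest of the two numbers; its nearest neighbour is compound 1, and the change a number 12.1 percentage points lower from compound 1 to compound 2 (beyond the scatter) runs beyond the scatter. Compound 3 `COc1cc(C(=O)N/N=C/c2cc(Cl)cc(Cl)c2)cc(OC)c1OC` has not been measured. It differs from compound 2 in this way: 3,5-dichlorophenyl in place of 3,4-dichlorophenyl on a carbon with a double bond to nitrogen. Going by the values given here, the only measured step, a number 12.1 percentage points lower from compound 1 to compound 2 (beyond the scatter), replaces one halogen pattern with another and is modest in size; no measured pair shows what moving a chlorine from one ring position to another does while keeping the same atoms. With nothing closer to lean on, the step of a number 1.3 percentage points higher from compound 2 to compound 3 (within the scatter) is expected to stay within the scatter. Compound 3 is therefore estimated at 34%, with a range from 20% to 50%.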

Compound 3, a percentage reported as inhibition, at one concentration (the size of the read-out at that concentration, not a potency): 9.2%
Beside the measured number, compound 3's estimate is 24.8 percentage points above it, outside the stated range (below it).
By their numbers in this assay, from the lowest: compound 3; then compound 2; then compound 1.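

In this assay, the change runs a number 23.5 percentage points lower from compound 2 to compound 3 (beyond the scatter) and shows what the earlier pair could not: at this place the arrangement of the chlorines matters in its own right. The 3,4-dichlorophenyl and 3,5-dichlorophenyl groups hold the same atoms, joined differently, yet the read-out separates them. Set against the 3-fluorophenyl group, the change is larger, a number 35.6 percentage points lower from compound 1 to compound 3 (beyond the scatter), which leaves the 3,5-dichlorophenyl group with the lowest number of the three, and nothing given here accounts for the gap.

The compounds shown leave open whether a single chlorine on this ring would give a number closer to that of the 3-fluorophenyl group or to that of the 3,5-dichlorophenyl group. They also leave open how a hydroxyl or an amine on the same ring would read.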